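From a piperazin-1-yl chain to a 4-methylpiperazin-1-yl chain

The compounds below may be only part of what the source reports. "The series", "measured", "known", "first", "only" and "open" are said of these compounds alone.

In a functional assay on A549 cells (Homo sapiens) for cytotoxicity, read by MTT assay, with a stated time of 72 h (a lower number here means a stronger inhibitor, a higher number a weaker inhibitor), compound 1 `O=C1c2c[n+]([O-])c3ccccc3c2C(=O)c2c1c1ccccc1n2Cc1cn(CC(O)CO)nn1` gives 880 nM and compound 2 `O=C1c2c[n+]([O-])c3ccccc3c2C(=O)c2c1c1ccccc1n2CCCCN1CCNCC1` gives 540 nM. Going by the values given here, these are the only two measured compounds, and they stand level, since the step between them, a 1.6-fold lower number from compound 1 to compound 2 (0.21 log units; within the scatter), lies within the scatter. Compound 3 `CN1CCN(CCCn2c3c(c4ccccc42)C(=O)c2c[n+]([O-])c4ccccc4c2C3=O)CC1` has the same atoms as compound 2, joined differently: 4-methylpiperazin-1-yl in place of (piperazin-1-yl)methyl on a saturated chain carbon, three bonds along the chain from an aromatic nitrogen. Among the compounds with values here, only that one measured step bears on this change, and it replaced a whole 1-(2,3-dihydroxypropyl)-1H-1,2,3-triazol-4-yl group with 3-(piperazin-1-yl)propyl. One step is thin evidence, but it gives no reason to expect a move beyond the scatter in this assay, so compound 2 at 540 nM serves as the anchor. The expected change is small, with an estimated 1.1-fold lower number from compound 2 to compound 3 (0.03 log units; within the scatter). Compound 3 is expected at 500 nM, with an estimated range of 200 nM to 1200 nM.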

Compound 3, half-maximal inhibitory concentration: 140 nM
For compound 3 the middle estimate is 3.6-fold (0.55 log units) above the measured one; measured number outside the range, below it.
By their numbers in this assay, from the lowest: compound 3; then compounds 2 and 1 (each within the scatter of the next).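

In this assay, going from 4-(piperazin-1-yl)butyl to 3-(4-methylpiperazin-1-yl)propyl gives a 3.9-fold lower number from compound 2 to compound 3 (0.59 log units; beyond the scatter) at this site, on a saturated chain carbon three bonds along the chain from an aromatic nitrogen. Going by these compounds alone, the same atoms joined differently thus move the number beyond the scatter, which the one earlier step, lying within the scatter, did not show. The replacement of the whole side group of compound 1 also now reads beyond the scatter, as a 6.3-fold lower number from compound 1 to compound 3 (0.80 log units; beyond the scatter) shows, although compound 2 stood level with compound 1. Nothing given here accounts for the gain.

The change shortens the chain and adds the methyl on the piperazine together, so the compounds shown leave open which of the two carries the step. A 4-(4-methylpiperazin-1-yl)butyl chain on the same core would separate them.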